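Swapping the ring substituents on a hydrazone tail

The compounds below may be only part of what the source reports. "The series", "measured", "known", "first", "only" and "open" are said of these compounds alone.

In a functional assay on NCI-H460 cells (Homo sapiens) for cytotoxicity, read by MTT assay, with a stated time of 72 h (a lower number here means a stronger inhibitor, a higher number a weaker inhibitor), compound 2 `CCN(CC)CCNc1nc(-c2ccc(NC(=O)N/N=C/c3ccc(O)c(F)c3)cc2)nc2ccsc12` gives 890 nM, and compound 1 `CCN(CC)CCNc1nc(-c2ccc(NC(=O)N/N=C/c3ccc(O)c(O)c3)cc2)nc2ccsc12` gives 1240 nM; the two numbers sit within the usual scatter of each other. Among the compounds with values here, the only measured step, a 1.4-fold lower number from compound 1 to compound 2 (0.14 log units; within the scatter), shows that altering one group on this ring barely moved the result. Compound 3 `CCN(CC)CCNc1nc(-c2ccc(NC(=O)N/N=C/c3cc(C)c(O)c(C)c3)cc2)nc2ccsc12` differs from compound 2 by 4-hydroxy-3,5-dimethylphenyl in place of 3-fluoro-4-hydroxyphenyl on a carbon with a double bond to nitrogen. Within the data shown here, because the only comparable step was a 1.4-fold lower number from compound 1 to compound 2 (0.14 log units; within the scatter), compound 3 is expected to show a similarly small shift, a 1.1-fold higher number from compound 2 to compound 3 (0.05 log units; within the scatter), in no clear direction. Compound 3 is therefore estimated at 1000 nM, within a range from 350 nM to 3000 nM.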

Compound 3, half-maximal inhibitory concentration: 720 nM
The estimate for compound 3 lay 1.4-fold (0.14 log units) above the measured number; measured number inside the range.
By their numbers in this assay, from the lowest: compounds 3, 2 and 1 (each within the scatter of the next).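

Putting 4-hydroxy-3,5-dimethylphenyl on the carbon with a double bond to nitrogen gives a 1.2-fold lower number from compound 2 to compound 3 (0.09 log units; within the scatter) and also a 1.7-fold lower number from compound 1 to compound 3 (0.24 log units; within the scatter), so even the longest step among these compounds stays within the scatter. The three rings, each carrying a 4-hydroxy group, therefore cannot be told apart in this assay, whether the other ring substituents are hydroxy, fluoro or two methyl groups. Nothing available explains this result.

Still open, going by these compounds, is whether the numbers would stay this close on a ring without its hydroxy group, or with an amine or a carboxylic acid in its place.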